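The source may report more compounds than this note shows. Statements on the series, on what has been measured and on what is new or still open speak of the compounds shown alone.

In a functional assay on HeLa cells (Homo sapiens) for inhibition (on this read-out lower numbers stand for stronger inhibition and higher numbers for weaker inhibition), three compounds have been measured:
- compound 1 `Nc1nc(O)c2ncn(/C=C/C=O)c2n1` gives 50000 nM as a number
- compound 2 `O=C/C=C/n1cc(C(F)(F)F)c(=O)[nH]c1=O` gives > 100000 nM as a limit
- compound 3 `Cc1cn(/C=C/C#N)c(=O)[nH]c1=O` gives > 100000 nM as a limit

Compound 3 gives no number of its own and stands on the limit of > 100000 nM in this assay, at which 2 of the 3 values shown sit, in the data so far. Compound 2 is the other compound at that limit. Compound 1 is the only one of the three with a measured number (50000 nM).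

Compound 4 `Cc1cn(/C=C/CO)c(=O)[nH]c1=O` departs from compound 3 in a single place, with hydroxymethyl in place of cyano on a double-bonded chain carbon bound to a double-bonded chain carbon. Within the data shown here, no measured pair shows what this exchange does in this assay, so any expectation has little to rest on. Compound 3 offers only a limit as a starting point (> 100000 nM). No step beyond the scatter is expected, and no direction can be argued from the data. The expected change is a number no higher from compound 3 to compound 4 (the limit leaves the size open) in this reading. For compound 4 the estimate is 100000 nM (expected range 40000 nM to 200000 nM), and a limit rather than a number is the likelier report.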

Compound 4, half-maximal inhibitory concentration: > 100000 nM
Compound 4: only a limit was reported; the forecaster's own chance of this, stated with the estimate: 70%; the middle value lies on the limit itself.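

Among these compounds, compound 3 and compound 4 both stand on a limit rather than a number in this assay, so no step between them can be read: the limit of > 100000 nM in this assay, at which 3 of the 4 values shown sit. The compounds shown leave open what hydroxymethyl in place of cyano does to inhibition in this assay, as they offer no pair with a measured number on both sides of that exchange.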